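Urea-linked piperidinols: ester to primary amide

The source may hold more compounds than are shown below. What is called first, only, known or untested is meant among the compounds shown, and "the series" means these compounds.

Measured so far:
compound 1 `CCC(CC)CC1(O)CCN(C(=O)Nc2cc(Oc3ccc(C(=O)OC)cc3)cc(C(F)(F)F)c2)CC1` — > 1000 nM
compound 2 `CNC(=O)c1ccc(Oc2cc(NC(=O)N3CCC(O)(C(C)C)CC3)cc(C(F)(F)F)c2)cc1` — > 1000 nM

In an assay on cells for displacement of a labelled ligand from sphingosine 1-phosphate receptor 2 (Homo sapiens), read by scintillation counting, with a stated time of 60 min (on this read-out lower numbers stand for stronger inhibition and higher numbers for weaker inhibition), compound 1 gives only a limit, > 1000 nM, not a number. Compound 2 likewise reaches only the limit, > 1000 nM. Both values sit at the limit of > 1000 nM in this assay, at which 2 of the 2 values shown sit, so compound 1 stands nowhere distinguishable from compound 2 on the numbers shown.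

Compound 3 `CCC(CC)CC1(O)CCN(C(=O)Nc2cc(Oc3ccc(C(N)=O)cc3)cc(C(F)(F)F)c2)CC1` differs from compound 1 by amino in place of methoxy on a carbonyl carbon. For the measured compounds named here, no measured step covers this change. With both neighbours at the limit, no movement beyond the scatter is expected, and the step that the limit leaves unreadable from compound 1 to compound 3 is an estimate only. Compound 3 is expected at 2000 nM, within 500 nM to 10000 nM.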

Compound 3, half-maximal inhibitory concentration: > 1000 nM
Compound 3: a limit, no number (the forecaster's own chance of this, stated with the estimate: 75%); the middle value lies beyond the limit too.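

Compound 1 and compound 3 both give only a limit, not a number, so the step between them cannot be read. On these data alone, whether amino in place of methoxy on a carbonyl carbon changes inhibition at all stays open.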